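Salicylanilide cytotoxicity: an acetyl group gives way to a chain

A few compounds are considered here, and "the series" means these few. Any claim that something is new, unique, unknown or untested is made for them only; others in the source may bear on it.

The compounds here share one core, a chlorinated salicylanilide, and differ only in the group carried on a nitrogen attached to one aromatic ring. Compound 1 `CCCNc1ccc(NC(=O)c2cc(Cl)ccc2O)c(Cl)c1` carries a propyl group there, and in an ADME assay on A549 cells (Homo sapiens) for cytotoxicity, read by LDH release, with a stated time of 15 h (a lower number here means that less compound is tolerated, a higher number that more compound is tolerated), compound 1 gives 69700 nM. Compound 2 `CC(=O)Nc1ccc(NC(=O)c2cc(Cl)ccc2O)c(Cl)c1` carries an acetyl group instead; in this assay compound 2 gives "not determined" (no result reported), so its standing cannot be fixed on any number.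

Compound 3 `CCCCCCC(C)Nc1ccc(NC(=O)c2cc(Cl)ccc2O)c(Cl)c1` is the next member, not yet measured in this assay. The change from compound 2 to compound 3 is 1-methylheptyl in place of acetyl on a nitrogen on an aromatic ring, so eight carbons with no acceptor replace the three-atom acetyl group.

Among the compounds with values here, no measured step leads from compound 2 to compound 3, so the size of the step cannot be stated. Within the data shown here, what is known is only that compound 1, with its propyl group on the same nitrogen, gives 69700 nM in this assay. Compound 3 is therefore expected to give 30000 nM, with a range from 8000 nM to 90000 nM.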

Compound 3, half-maximal cytotoxic concentration: 18600 nM
Beside the measured number, compound 3's estimate is 1.6-fold (0.21 log units) above it; the range from low to high includes it.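

In this assay, putting 1-methylheptyl in place of propyl on the nitrogen on the aromatic ring gives a 3.7-fold lower number from compound 1 to compound 3 (0.57 log units; beyond the scatter), a modest shift but one beyond the usual scatter, so the group at this position does affect how much compound the cells tolerate. Within the data shown here, the step from the acetyl compound cannot be read, as compound 2 has no number, so the only comparison available is between the two chains and the effect of removing acetyl remains unknown. No measurement here bears on why the longer group lowers the number, so the data show the size of the change but give no explanation for it.

Among these compounds, two measured compounds give only one step, which cannot show whether the number falls steadily as the chain grows or whether the change depends on the particular shape of 1-methylheptyl; a straight octyl chain or a butyl chain at the same nitrogen would help to separate those readings. As far as these compounds go, it also remains open how the number would respond to a chain ending in an amine or a carboxylic acid.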